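The source may hold more compounds than are shown below. What is called first, only, known or untested is meant among the compounds shown, and "the series" means these compounds.

Compound 1, `N#Cc1c(Nc2cccc(C(F)(F)F)c2)nc(SCc2cn(Cc3ccccc3Cl)nn2)nc1-c1ccccc1`, gives 32000 nM in a functional assay on ECa-109 cells (Homo sapiens) for inhibition, read by MTT assay, with a stated time of 72 h; on this read-out higher numbers stand for weaker inhibition and lower numbers for stronger inhibition.
Compound 2, `N#Cc1c(Nc2ccc(F)cc2)nc(SCc2cn(Cc3ccccc3Cl)nn2)nc1-c1ccccc1`, gives 25800 nM in this assay.

Only these two compounds have been measured in this assay, and compound 2 stands as one of the pair, separated from compound 1 by a 1.2-fold lower number from compound 1 to compound 2 (0.09 log units; within the scatter), a gap that does not rise above the scatter. Compound 3, `Cc1ccccc1Nc1nc(SCc2cn(Cc3ccccc3Cl)nn2)nc(-c2ccccc2)c1C#N`, remains to be measured. It differs from compound 2 by 2-methylphenyl in place of 4-fluorophenyl on a nitrogen on an aromatic ring; the same difference, cut one bond further out, reads (4-fluorophenyl)amino to (2-methylphenyl)amino. Within the data shown here, the single measured step that bears on this change is the exchange of one aryl group on the same nitrogen, a 1.2-fold lower number from compound 1 to compound 2 (0.09 log units; within the scatter), which stayed within the scatter. On that basis no step beyond the scatter is expected for compound 3 in this assay, in either direction. Compound 3 is therefore estimated at 26000 nM, with a range from 10000 nM to 65000 nM. That expectation amounts to a step of a 1.0-fold higher number from compound 2 to compound 3 (0.00 log units; within the scatter).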

Compound 3, half-maximal inhibitory concentration: 9740 nM
The estimate for compound 3 lay 2.7-fold (0.43 log units) above the measured number; measured number below the stated range.
By their numbers in this assay, from the lowest: compound 3; then compounds 2 and 1 (each within the scatter of the next).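

In this assay, among these compounds, the group on a nitrogen on an aromatic ring now moves the number beyond the scatter, which the one earlier exchange at this position had not done: 2-methylphenyl in place of 4-fluorophenyl gives a 2.6-fold lower number from compound 2 to compound 3 (0.42 log units; beyond the scatter) and stands as a modest step. Against 3-(trifluoromethyl)phenyl the same entering group gives a 3.3-fold lower number from compound 1 to compound 3 (0.52 log units; beyond the scatter) and is again modest, so among these three compounds 2-methylphenyl stands apart from both other aryl groups. Nothing available here accounts for this difference.

Still open, going by these compounds, is whether a longer alkyl chain in place of the methyl of 2-methylphenyl, or a carboxylic acid on that phenyl ring, would carry the number further or reverse it. On these data alone, all three compounds share the rest of their structure, so whether this step would hold with a different group elsewhere on the core also remains unknown.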